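From Propyl to Methoxy, Starting from Limits

The source may report more compounds than this note shows. Statements on the series, on what has been measured and on what is new or still open speak of the compounds shown alone.

In a functional assay on KB cells (Homo sapiens) for antiproliferative activity, read by sulforhodamine B assay, with a stated time of 3 days (on this read-out lower numbers stand for an effect already at smaller amounts and higher numbers for an effect only at larger amounts of compound), compound 1 (`CCC1=C(O)c2c(oc(-c3ccccc3)cc2=O)C(CC)(CC)C1=O`) gives > 236 uM, which is a limit. Compound 2 (`CCCc1ccc(-c2cc(=O)c3c(o2)C(CC)(CC)C(=O)C(CC)=C3O)cc1`) gives > 53 uM, also only a limit, so it has no exact place on the scale. Compound 3 (`CCC1=C(O)c2c(oc(-c3ccc(OC)cc3)cc2=O)C(CC)(CC)C1=O`) carries methoxy in place of propyl on an aromatic carbon. Going by the values given here, the one measured step is a step that the two limits leave unreadable from compound 1 to compound 2, so it offers no size to carry over. No clear change in either direction is therefore expected, and the estimated step is a step that the limit leaves unreadable from compound 2 to compound 3. For compound 3 the expected value is 80 uM, with an estimated range from 25 uM to 250 uM, and it may well prove another limit.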

Compound 3, concentration for half-maximal effect: 17.7 uM
Estimate against measurement, compound 3: 4.5-fold (0.66 log units) above; measured number below the stated range.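

Methoxy on this aromatic carbon, para to a large group, gives the first readable step here: an at least 2.9-fold lower number from compound 2 to compound 3 (0.47 log units; beyond the scatter). Set against hydrogen at the same place, it gives an at least 13-fold lower number from compound 1 to compound 3 (1.12 log units; beyond the scatter). The true size of the step away from propyl stays unknown, because that step starts from a limit: the limit of > 53 uM in this assay, at which 1 of the 3 values shown sits.

The compounds shown cannot separate the effect of the oxygen in methoxy from that of the change in chain. On these data alone, whether ethoxy, hydroxyl or an amine at this place would give a similar number remains open.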